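This account rests on a few compounds, and the source may have more. Where it says the series, first, only, none or still open, it means among the compounds named here.

In a functional assay on SK-MEL-28 cells (Homo sapiens) for cytotoxicity, read by MTT assay (on this read-out higher numbers stand for weaker inhibition and lower numbers for stronger inhibition), compound 1 `O=C(NCCNc1nccc(-c2c(-c3cccc(F)c3)nc3sccn23)n1)c1c(F)cccc1F` gives 11400 nM. Its number stands beside those of the two other measured compounds: compound 3 `O=S(=O)(NCCCNc1nccc(-c2c(-c3cccc(F)c3)nc3sccn23)n1)c1ccc(C(F)(F)F)cc1` gives 11700 nM and compound 2 `COc1ccc(S(=O)(=O)NCCCNc2nccc(-c3c(-c4cccc(F)c4)nc4sccn34)n2)cc1` gives 8980 nM, and both gaps to compound 1 lie within the scatter. Among the compounds with values here, the one measured step, a 1.3-fold higher number from compound 2 to compound 3 (0.11 log units; within the scatter), concerns a sulfonamide aryl and is itself within the scatter. Compound 4 `O=C(NCCNc1nccc(-c2c(-c3cccc(F)c3)nc3sccn23)n1)c1ccc(Cl)cc1` arises from compound 1 through (4-chlorophenyl in place of 2,6-difluorophenyl on a carbonyl carbon). Within the data shown here, no measured step touches the amide aryl, so nothing in the numbers points to a shift in either direction; the expectation is therefore a step of a 1.0-fold lower number from compound 1 to compound 4 (0.02 log units; within the scatter), that is, none beyond the scatter. Compound 4 is thus expected to give about 11000 nM, in the range 4000 nM to 30000 nM.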

Compound 4, half-maximal inhibitory concentration: 8160 nM
For compound 4 the middle estimate is 1.3-fold (0.13 log units) above the measured one; measured number inside the range.
By their numbers in this assay, from the lowest: compounds 4, 2, 1 and 3 (each within the scatter of the next).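

Within the data shown here, putting 4-chlorophenyl in place of 2,6-difluorophenyl on the carbonyl carbon is the first change to this aryl group that can be read, and in this assay it gives a 1.4-fold lower number from compound 1 to compound 4 (0.15 log units; within the scatter) and stays within the scatter. This position therefore accepts the loss of both fluorines and the entry of one chlorine with no change that stands out from the scatter. Nothing measured here bears on the reason for the size of this step.

As far as these compounds go, whether a phenyl carrying an amine or a carboxylic acid, or a cyclohexyl in place of the aryl, would move the number beyond the scatter remains open. So does the effect of a longer chain in place of the ethyl linker in compound 1.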